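Compound 4: fluoro in place of hydroxy

A few compounds are considered here, and "the series" means these few. Any claim that something is new, unique, unknown or untested is made for them only; others in the source may bear on it.

Three compounds share one core and differ in a single group on the aromatic ring. In a functional assay on KB cells (Homo sapiens) for cytotoxicity (a higher number here means that more compound is needed for the effect, a lower number that less compound is needed), compound 1 (`COC1=C(C)C(=O)/C(=C(O)/C=C/c2ccc(Br)cc2)C(=O)C1(C)C`) gives 1.9 ug/mL, compound 2 (`COC1=C(C)C(=O)/C(=C(O)/C=C/c2ccc(OC)cc2)C(=O)C1(C)C`) gives 2.9 ug/mL and compound 3 (`COC1=C(C)C(=O)/C(=C(O)/C=C/c2ccc(O)cc2)C(=O)C1(C)C`) gives 3 ug/mL. Compound 3 therefore lies within the scatter of both other compounds, and none of the three separates from the rest.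

The next step leads to compound 4 (`COC1=C(C)C(=O)/C(=C(O)/C=C/c2ccc(F)cc2)C(=O)C1(C)C`), which carries 4-fluorophenyl where compound 3 carries 4-hydroxyphenyl: fluoro in place of hydroxy on an aromatic carbon. Three measured steps at this same place bear on it. Methoxy in place of bromo gives a 1.5-fold higher number from compound 1 to compound 2 (0.18 log units; within the scatter), hydroxy in place of bromo gives a 1.6-fold higher number from compound 1 to compound 3 (0.20 log units; within the scatter), and hydrogen in place of methyl on the oxygen gives a 1.0-fold higher number from compound 2 to compound 3 (0.01 log units; within the scatter). All three stay within the scatter. Within the data shown here, no measured compound carries fluoro, so the nearest guide is the other halogen, in compound 1 at 1.9 ug/mL. On these steps, no change beyond the scatter is expected in this assay, and the expected step is a 1.3-fold lower number from compound 3 to compound 4 (0.10 log units; within the scatter). For compound 4 the estimate is 2.4 ug/mL, with an expected range from 1.2 ug/mL to 4.5 ug/mL.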

Compound 4, concentration for half-maximal effect: 2.7 ug/mL
For compound 4 the middle estimate is 1.1-fold (0.05 log units) below the measured one; measured number inside the range.
By their numbers in this assay, from the lowest: compounds 1, 4, 2 and 3 (each within the scatter of the next).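

With fluoro in place of hydroxy on an aromatic carbon, para to a large group, this assay still shows no separation (a 1.1-fold lower number from compound 3 to compound 4 (0.05 log units; within the scatter)), so the loss of the hydrogen-bond donor and acceptor counted for hydroxy leaves the read-out within the scatter at this position. Among these compounds, the same holds against the other two groups, both for fluoro in place of methoxy (a 1.1-fold lower number from compound 2 to compound 4 (0.03 log units; within the scatter)) and for fluoro in place of bromo (a 1.4-fold higher number from compound 1 to compound 4 (0.15 log units; within the scatter)), so the two halogens do not separate from each other and all four groups now form one unresolved set, with no compound going against this. No measurement bearing on the reason for this flat result is available.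

From the compounds shown here alone, whether any group at this position can move the number beyond the scatter remains open, since a primary amine, a carboxylic acid or a longer alkyl chain in place of these four groups would test a wider range of substituents. Also open, going by these compounds, is whether the shared core responds more strongly than this position does, for instance when its ring methoxy group or its enol hydroxy group is exchanged.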